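The source may hold more compounds than are shown below. What is called first, only, known or untested is meant among the compounds shown, and "the series" means these compounds.

Working notes on the series

The shared core is seen in compound 2, `CSc1nc(NCc2ccccc2)c2ccccc2n1`, and the series is followed in a functional assay on HT-29 cells (Homo sapiens) for cytotoxicity, read by MTT assay, with a stated time of 72 h; a lower number here means that less compound is tolerated, a higher number that more compound is tolerated. In this assay compound 2 gives only a limit, > 100000 nM, and no number. Compound 1, `C[Se]c1nc(NCc2ccccc2)c2ccccc2n1`, carries the change (a group of 2 heavy atoms (1 carbon, 1 selenium; no ring) in place of a group of 2 heavy atoms (1 carbon, 1 sulfur; no ring), on an aromatic carbon). In this assay compound 1 likewise gives a limit, > 100000 nM. Compound 3, `CSc1ccc(CNc2nc(SC)nc3ccccc23)cc1`, carries the change (methylsulfanyl in place of hydrogen on an aromatic carbon). In this assay compound 3 also gives a limit, > 100000 nM. The two steps from the parent are thus a step that the two limits leave unreadable from compound 2 to compound 1 and a step that the two limits leave unreadable from compound 2 to compound 3, and neither can be sized, since the limit of > 100000 nM in this assay, at which 3 of the 3 values shown sit, holds all values shown.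

Compound 4, `CSc1ccc(CNc2nc([Se]C)nc3ccccc23)cc1`, is not yet measured. It differs from compound 3 by a group of 2 heavy atoms (1 carbon, 1 selenium; no ring) in place of a group of 2 heavy atoms (1 carbon, 1 sulfur; no ring), on an aromatic carbon. Among the measured compounds shown here, this is the same kind of change as the one from compound 2 to compound 1, but the surroundings are not identical, since the two cores are not the same. How the two cores differ is given by methylsulfanyl in place of hydrogen on an aromatic carbon.

For compound 4 the step that the limit leaves unreadable from compound 3 to compound 4 is expected, resting on the step from compound 2 to compound 1 having stayed within the limit. Compound 4 is accordingly expected to give 150000 nM, most likely again as a limit, with a range of 100000 nM to 300000 nM.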

Compound 4, concentration lethal to 50% of the cells: > 100000 nM
Compound 4: no number, only a limit (the forecaster's own chance of this, stated with the estimate: 85%); the middle value is on the limit's open side.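

In this assay compound 4 gives > 100000 nM, a limit and not a number. No step can be read from compound 3 to compound 4 or from compound 1 to compound 4, because all the values share one limit: the limit of > 100000 nM in this assay, at which 4 of the 4 values shown sit.

The compounds shown leave open whether either change, selenium-bearing group for methylsulfanyl or methylsulfanyl for hydrogen, has any effect on cytotoxicity in this assay.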